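Swapping methoxy for hydroxy on a pyrazole cytotoxicity series

A few compounds are considered here, and "the series" means these few. Any claim that something is new, unique, unknown or untested is made for them only; others in the source may bear on it.

Measured compounds:
- compound 1 `COc1cc(C)cc(-c2c(-c3ccnc(-c4ccc(C(C)=O)cc4)c3)cnn2CC#N)c1`: 78%
- compound 2 `Cc1cc(O)cc(-c2nn(CC#N)cc2-c2ccnc(-c3ccc(Oc4ccccc4)cc3)c2)c1`: 79%
- compound 3 `COc1cc(C)cc(-c2nn(CC#N)cc2-c2ccnc(-c3ccc(N(C)C)cc3)c2)c1`: 98%

The three compounds were tested in a functional assay on SNB-75 cells (Homo sapiens) for cytotoxicity, read by sulforhodamine B assay, with a stated time of 48 h, tested at 0.01 uM; on this read-out lower numbers stand for a stronger effect and higher numbers for a weaker effect at the one concentration tested. Compound 3 stands highest of the three numbers: in this assay compound 3 gives 98%, which is beyond the scatter away from compound 2 and from compound 1, so its effect at this concentration is the weakest of the set.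

Compound 4 `Cc1cc(O)cc(-c2nn(CC#N)cc2-c2ccnc(-c3ccc(N(C)C)cc3)c2)c1` is not yet measured. It differs from compound 3 in one place: hydrogen in place of methyl on an oxygen on an aromatic ring. For the measured compounds named here, no pair of measured compounds shows this change on its own, as compound 2, the only hydroxy compound, also carries a different tail than compound 1 or compound 3. Without such a reference, the expected step in this assay is a small move toward a lower number, not clearly beyond the scatter, written as a number 6 percentage points lower from compound 3 to compound 4 (within the scatter). On that basis compound 4 is estimated at 92%, with a range from 78% to 104%.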

Compound 4, a percentage reported as activity, at one concentration (the size of the read-out at that concentration, not a potency): 75%
For compound 4 the middle estimate is 17 percentage points above the measured one; measured number below the stated range.
By their numbers in this assay, from the lowest: compounds 4, 1 and 2 (each within the scatter of the next); then compound 3.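

In this assay, turning methoxy into hydroxy on the 3-methoxy-5-methylphenyl group, with the dimethylamino group unchanged, gives a number 23 percentage points lower from compound 3 to compound 4 (beyond the scatter). This is the one clean view of the change, and it shows that losing a single methyl from that oxygen is enough to move the read-out beyond the usual scatter. With hydroxy in place, dimethylamino instead of phenoxy gives a number 4 percentage points lower from compound 2 to compound 4 (within the scatter), so the two hydroxy compounds cannot be told apart here, and nothing available explains the effect of the methyl.

Going by these compounds, whether the hydroxy step also holds alongside the phenoxy group remains open, since this one pair cannot show it. On these data alone, what an ethoxy group or an amine would do at the same position also remains open.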